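Working notes: chloro in place of nitro, compound 3

The source may hold more compounds than are shown below. What is called first, only, known or untested is meant among the compounds shown, and "the series" means these compounds.

Measured so far in a functional assay on HL-60 cells (Homo sapiens) for inhibition, read by CCK-8 assay, with a stated time of 48 h, tested at 20 uM; on this read-out lower numbers stand for less inhibition of growth and higher numbers for more inhibition of growth at the one concentration tested
compound 1 `N#C/C(=C\c1ccccc1OS(=O)(=O)c1ccc(Cl)cc1)C(=O)Nc1nnc(-c2cccc(F)c2)s1` gives 42%
compound 2 `Cc1ccc(Cc2nnc(NC(=O)/C(C#N)=C/c3ccccc3OS(=O)(=O)c3ccc([N+](=O)[O-])cc3)s2)cc1` gives 17%

Of these two numbers, compound 2 holds the lower one, and the gap up to compound 1 lies beyond the usual scatter. The next compound to be read in this assay is compound 3 `Cc1ccc(Cc2nnc(NC(=O)/C(C#N)=C/c3ccccc3OS(=O)(=O)c3ccc(Cl)cc3)s2)cc1` and it departs from compound 2 by one change: chloro in place of nitro on an aromatic carbon para to a large group. Within the data shown here, no step between measured compounds isolates this change, so its size can only be judged indirectly. Compound 1 carries the same 4-chlorophenyl group and gives 42% but it also differs from compound 2 elsewhere, which makes it a weak guide. A moderate rise in growth inhibition is expected, only a little beyond the scatter, and a result within the scatter would not be surprising. The expected change is a number 13 percentage points higher from compound 2 to compound 3 (beyond the scatter) as an estimate from this one comparison. For compound 3 the estimated value is 30% with an expected range from 14% to 48% on repeat measurement.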

Compound 3, percent growth inhibition at one concentration: 38%
Beside the measured number, compound 3's estimate is 8 percentage points below it; the range from low to high includes it.
By their numbers in this assay, from the lowest: compound 2; then compounds 3 and 1 (each within the scatter of the next).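

In this assay, the exchange from 4-nitrophenyl to 4-chlorophenyl now has a direct reading, a number 21 percentage points higher from compound 2 to compound 3 (beyond the scatter), with the rest of the molecule held constant, so this position para to a large group does affect growth inhibition, at least on the 4-methylbenzyl background. Among these compounds, with the 4-chlorophenyl group held fixed, the other site can also be read for the first time: 4-methylbenzyl in place of 3-fluorophenyl gives a number 4 percentage points lower from compound 1 to compound 3 (within the scatter), so this exchange shows no change that can be told from scatter at this single concentration. The data offer no measured basis for explaining why chloro and nitro part in this way.

Going by these compounds, whether a methoxy group, an amine or a plain hydrogen in the same place would read nearer to chloro or to nitro remains open, since the position is so far defined by only these two groups. Also open, on these data alone, is whether the chloro-for-nitro step keeps its size with 3-fluorophenyl on the other side of the core, and whether it would hold at concentrations other than the one tested.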